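The compounds below may be only part of what the source reports. "The series", "measured", "known", "first", "only" and "open" are said of these compounds alone.

Series notes. Compound 1 `FC(F)(F)c1ccc(CN2CCN(Cc3cc(-c4ccc(OCc5ccccc5)cc4)on3)CC2)cc1` carries a benzyloxy group on the shared core; in a functional assay on Huh-7 cells (Homo sapiens) for antiproliferative activity, read by sulforhodamine B assay, with a stated time of 72 h (on this read-out higher numbers stand for weaker inhibition and lower numbers for stronger inhibition), compound 1 gives 1700 nM. Compound 2 `COc1ccccc1COc1ccc(-c2cc(CN3CCN(Cc4ccc(C(F)(F)F)cc4)CC3)no2)cc1` differs from compound 1 by methoxy in place of hydrogen on an aromatic carbon; in this assay compound 2 gives 900 nM, a step of a 1.9-fold lower number from compound 1 to compound 2 (0.28 log units; within the scatter). Compound 3 `COc1cc(COc2ccc(-c3cc(CN4CCN(Cc5ccc(C(F)(F)F)cc5)CC4)no3)cc2)cc(OC)c1` differs from compound 1 by 3,5-dimethoxyphenyl in place of phenyl on a saturated chain carbon bound to an oxygen on an aromatic ring; in this assay compound 3 gives 1500 nM, with a 1.1-fold lower number from compound 1 to compound 3 (0.05 log units; within the scatter) and a 1.7-fold higher number from compound 2 to compound 3 (0.22 log units; within the scatter). Compound 4 `COc1cc(COc2ccc(-c3cc(CN4CCN(Cc5ccc(C(F)(F)F)cc5)CC4)no3)cc2)cc(OC)c1OC` is not yet measured; it differs from compound 3 by methoxy in place of hydrogen on an aromatic carbon. Within the data shown here, this is the same kind of change as the one from compound 1 to compound 2, not the same one: in compound 2 the entering methoxy sits ortho to a large group, whereas in compound 4 it sits ortho to two methoxy groups and para to a large group. Because a 1.9-fold lower number from compound 1 to compound 2 (0.28 log units; within the scatter) lies within the scatter, the step expected here is a 1.4-fold lower number from compound 3 to compound 4 (0.13 log units; within the scatter), resting on that single earlier step and on compound 3 at 1500 nM. Compound 4 is therefore expected to give about 1100 nM in this assay, most likely between 400 nM and 3000 nM.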

Compound 4, half-maximal inhibitory concentration: 500 nM
Estimate against measurement, compound 4: 2.2-fold (0.34 log units) above; low and high end bracket the measured number.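

In this assay, methoxy in place of hydrogen on an aromatic carbon can now be read on two cores, and the two steps cannot be told apart: the same change on two cores in this assay, a 1.9-fold lower number (0.28 log units; within the scatter) from compound 1 to compound 2 and a 3.0-fold lower number (0.48 log units; beyond the scatter) from compound 3 to compound 4, 1.6-fold (0.20 log units) apart, within the scatter of two such steps. This fits a change that carries from one core to the other, but it rests on two pairs only, the earlier step lies within the scatter while a 3.0-fold lower number from compound 3 to compound 4 (0.48 log units; beyond the scatter) lies beyond it, and the entering methoxy has different surroundings in each pair, so neither a fixed step size nor a general rule is shown. The 3,4,5-trimethoxyphenyl group of compound 4 gives a 3.4-fold lower number from compound 1 to compound 4 (0.53 log units; beyond the scatter), whereas a 1.8-fold lower number from compound 2 to compound 4 (0.26 log units; within the scatter), so no order can be set between that pair.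

The compounds shown leave open whether the step persists when ethoxy or hydroxy groups replace the methoxy groups. From the compounds shown here alone, it is also open whether the step holds with a nitrile or a carboxylic acid in place of the trifluoromethyl group.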